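Swapping Isopropyl for Hydroxypropyl on the Amide Side Chain

The compounds below may be only part of what the source reports. "The series", "measured", "known", "first", "only" and "open" are said of these compounds alone.

Of the compounds shown here, three sharing one core have been tested in a functional assay on PC-3 cells (Homo sapiens) for antiproliferative activity, read by MTT assay, with a stated time of 24 h; on this read-out lower numbers stand for stronger inhibition and higher numbers for weaker inhibition. Compound 1 `CCn1c(C(=O)NCCN)ccc1C(CC)(CC)c1ccc(OCS(=O)(=O)c2ccccc2)c(C)c1` gives 6890 nM, compound 2 `CCn1c(C(=O)NCCO)ccc1C(CC)(CC)c1ccc(OCS(=O)(=O)c2ccccc2)c(C)c1` gives 17700 nM, and compound 3 `CCn1c(C(=O)N[C@H](CO)C(C)C)ccc1C(CC)(CC)c1ccc(OCS(=O)(=O)c2ccccc2)c(C)c1` gives 7300 nM. Compound 3 stands second highest of the three numbers, within the scatter of compound 1, while the step of a 2.4-fold lower number from compound 2 to compound 3 (0.38 log units; beyond the scatter) lies beyond the scatter. The new compound 4 `CCn1c(C(=O)N[C@H](CO)CCCO)ccc1C(CC)(CC)c1ccc(OCS(=O)(=O)c2ccccc2)c(C)c1` differs from compound 3 by 3-hydroxypropyl in place of isopropyl on a saturated chain carbon bound to an amide-type nitrogen and a saturated chain carbon. Two earlier steps bear on this: a 2.6-fold higher number from compound 1 to compound 2 (0.41 log units; beyond the scatter), where a hydroxy entered, and a 2.4-fold lower number from compound 2 to compound 3 (0.38 log units; beyond the scatter), where an isopropyl entered. Losing the isopropyl and gaining a hydroxy-bearing chain therefore suggests a modest rise. For compound 4 the expected step is a 1.5-fold higher number from compound 3 to compound 4 (0.18 log units; within the scatter). Compound 4 is estimated at 11000 nM, likely between 5000 nM and 25000 nM.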

Compound 4, half-maximal inhibitory concentration: 6810 nM
Estimate against measurement, compound 4: 1.6-fold (0.21 log units) above, and the stated range covers the measured number.
By their numbers in this assay, from the lowest: compounds 4, 1 and 3 (each within the scatter of the next); then compound 2.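

On the saturated chain carbon bound to the amide-type nitrogen, 3-hydroxypropyl serves as well as isopropyl, with a 1.1-fold lower number from compound 3 to compound 4 (0.03 log units; within the scatter), so a chain ending in hydroxy is tolerated at this position. Compared with the unsubstituted chain there is a 2.6-fold lower number from compound 2 to compound 4 (0.41 log units; beyond the scatter), and compared with the aminoethyl amide there is a 1.0-fold lower number from compound 1 to compound 4 (0.01 log units; within the scatter), which puts the two on a level. Nothing available explains these steps. From the compounds shown here alone, whether an amine or a carboxylic acid at the end of this chain, or a longer chain, would hold the same level remains open.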